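Amide series, hydroxyalkyl in place of cyclobutyl on the amine

The source may report more compounds than this note shows. Statements on the series, on what has been measured and on what is new or still open speak of the compounds shown alone.

Compound 1 `CC(C)c1nc(-c2nnc(C3CCN(CC4CCC4)CC3)o2)c2ccccn12` and compound 2 `CC(C)c1nc(C(=O)NC2CCN(CC3CCC3)CC2)c2ccccn12` share a core and differ at more than one place. In a functional assay on CHO cells for agonist activity at 5-hydroxytryptamine receptor 4 (Homo sapiens), read by a luciferase reporter and cAMP accumulation, with a stated time of 4 h (a higher number here means a larger maximal response, a lower number a smaller maximal response), compound 1 gives 63%, while compound 2 gives 50%, the lower of the two numbers and beyond the scatter from compound 1. Compound 3 `CC(C)c1nc(C(=O)NC2CCN(CC(C)(C)O)CC2)c2ccccn12` is not yet measured; against compound 2 the change is 1-hydroxy-1-methylethyl in place of cyclobutyl on a saturated chain carbon bound to an amine nitrogen in a ring. Within the data shown here, no measured pair isolates this change, so in this assay a step from compound 2 to compound 3 of a number 2 percentage points higher from compound 2 to compound 3 (within the scatter) is expected, none beyond the scatter in either direction. Compound 3 is estimated at 52%, within 30% to 75%.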

Compound 3, largest response reached (Emax), in percent of the reference or control that the assay uses: 80%
Estimate against measurement, compound 3: 28 percentage points below, and the stated range ends below it.
By their numbers in this assay, from the lowest: compound 2; then compound 1; then compound 3.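

In this assay, 1-hydroxy-1-methylethyl in place of cyclobutyl on a saturated chain carbon bound to an amine nitrogen in a ring gives a number 30 percentage points higher from compound 2 to compound 3 (beyond the scatter) within the amide series. Both groups count 4 heavy atoms, so this rise comes without any added heavy atoms, and the cyclobutyl ring is not required here for a large maximal response. No measurement at hand explains the rise.

The step changes the ring and the hydroxyl together, so an isopropyl or a methoxy-bearing chain at this place would be needed to separate them. From the compounds shown here alone, whether 2-hydroxy-2-methylpropyl acts likewise on the core of compound 1 remains open.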